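One aryl swap on a shared core

This account rests on a few compounds, and the source may have more. Where it says the series, first, only, none or still open, it means among the compounds named here.

Compound 1 `CCc1ccc(NC2=CC(=O)c3nc4n(c3C2=O)[C@H]2OC[C@@H](O)[C@H]2OC4)cc1` – 3080 nM
Compound 2 `Cc1ccc(NC2=CC(=O)c3nc4n(c3C2=O)[C@H]2OC[C@@H](O)[C@H]2OC4)cc1C` – 2820 nM

Both compounds were tested in a functional assay on ECa-109 cells for inhibition, with ECa-109 cell line (Homo sapiens) as the target, read by sulforhodamine B assay (a lower number here means a stronger inhibitor, a higher number a weaker inhibitor), and differ only in the aryl group on an amine nitrogen of the shared core. Compound 2 (at 2820 nM) lies within the scatter of compound 1 (at 3080 nM), so the two cannot be ranked.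

The next compound is compound 3 `COc1cccc(NC2=CC(=O)c3nc4n(c3C2=O)[C@H]2OC[C@@H](O)[C@H]2OC4)c1`, which carries 3-methoxyphenyl in place of 3,4-dimethylphenyl on an amine nitrogen. Within the data shown here, only one measured step bears on this change: a 1.1-fold lower number from compound 1 to compound 2 (0.04 log units; within the scatter), an exchange of aryl groups at the same place. It offers only partial guidance, since neither of its compounds carries a methoxy group. On the evidence of that step (a 1.1-fold lower number from compound 1 to compound 2 (0.04 log units; within the scatter)), no change beyond the scatter is expected in this assay, and no direction can be favoured. The estimated step is small (a 1.1-fold higher number from compound 2 to compound 3 (0.03 log units; within the scatter)). For compound 3 the expected value is 3000 nM (estimated range from 1200 nM to 7500 nM).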

Compound 3, half-maximal inhibitory concentration: 7620 nM
The estimate for compound 3 lay 2.5-fold (0.40 log units) below the measured number, outside the stated range (above it).
By their numbers in this assay, from the lowest: compounds 2 and 1 (each within the scatter of the next); then compound 3.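

Among these compounds, until now, the only exchange at this amine nitrogen had stayed within the scatter, so the aryl group there could have seemed to make little difference in this assay. Compound 3 shows otherwise: 3-methoxyphenyl in place of 3,4-dimethylphenyl gives (a 2.7-fold higher number from compound 2 to compound 3 (0.43 log units; beyond the scatter)), and 3-methoxyphenyl in place of 4-ethylphenyl gives (a 2.5-fold higher number from compound 1 to compound 3 (0.39 log units; beyond the scatter)), two modest steps in the same direction from two aryl groups that cannot be ranked against each other. The change brings in an oxygen and one hydrogen-bond acceptor and also alters the substitution on the ring, but nothing available ties the higher number to any of these features or offers a reason for it.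

As far as these compounds go, it remains open whether the step follows the methoxy group itself or where it stands on the ring, a question that 4-methoxyphenyl and 3-methylphenyl groups at the same nitrogen would help to separate. How other groups on this aryl ring, such as a hydroxyl, a chlorine or an amine, would read in this assay is also left open.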